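Adding a 3,4-difluorobenzyl group onto compound 3

The source may hold more compounds than are shown below. What is called first, only, known or untested is meant among the compounds shown, and "the series" means these compounds.

Measured compounds:
compound 1 `C#CCN(CCCOc1ccc2ccc(=O)oc2c1)Cc1ccc(OC)cc1`, 6080 nM
compound 2 `C#CCN(CCCOc1ccc2ccc(=O)oc2c1)Cc1ccc(C)cc1`, 7380 nM
compound 3 `C#CCN(C)CCCOc1ccc2ccc(=O)oc2c1`, 1090 nM

In an assay on isolated protein for inhibition of Amine oxidase [flavin-containing] B (Homo sapiens), read by fluorescence and Amplex Red, with stated times of 15 min and 20 min (on this read-out lower numbers stand for stronger inhibition and higher numbers for weaker inhibition), compound 3 gives 1090 nM, the lowest number of the three and therefore the strongest inhibition shown here. Compound 4 `C#CCN(CCCOc1ccc2ccc(=O)oc2c1)Cc1ccc(F)c(F)c1` is not yet measured; it differs from compound 3 by 3,4-difluorophenyl in place of hydrogen on a saturated chain carbon bound to an amine nitrogen.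

Among the compounds with values here, two measured steps bear on this change, both read in the opposite direction. Going a 5.6-fold lower number from compound 1 to compound 3 (0.75 log units; beyond the scatter), and going a 6.8-fold lower number from compound 2 to compound 3 (0.83 log units; beyond the scatter); in each case removing a substituted benzyl group from the amine nitrogen and leaving a methyl made the number lower. Compound 1 and compound 2 themselves are within the scatter of each other, so the substituent on that ring made little difference. A third substituted benzyl group on compound 3 is therefore expected to push the number back up by a comparable amount, giving a 5.0-fold higher number from compound 3 to compound 4 (0.70 log units; beyond the scatter). For compound 4 the expected value is 5500 nM, with a range from 2500 nM to 12000 nM.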

Compound 4, half-maximal inhibitory concentration: 4860 nM
Compound 4: middle estimate off by 1.1-fold (0.05 log units), on the high side; the range from low to high includes it.
By their numbers in this assay, from the lowest: compound 3; then compounds 4, 1 and 2 (each within the scatter of the next).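

In this assay, the 3,4-difluorobenzyl group in place of methyl on the amine nitrogen also weakens inhibition, with a 4.5-fold higher number from compound 3 to compound 4 (0.65 log units; beyond the scatter), so the loss now holds for three different benzyl groups, and none of the compounds shown goes against it. The ring's substituents still make no clear difference, since a 1.5-fold lower number from compound 2 to compound 4 (0.18 log units; within the scatter) and a 1.3-fold lower number from compound 1 to compound 4 (0.10 log units; within the scatter), which means that two fluorines on the ring perform like a single methyl or methoxy group here. No measurement shown explains why the benzyl groups give higher numbers than the methyl group.

The compounds shown leave open whether a hydrogen or an ethyl group on the amine nitrogen would give a lower number than compound 3. On these data alone, it also remains open whether a longer chain between the nitrogen and the aromatic ring, as in a 2-phenylethyl group, would recover any of the lost inhibition.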